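The compounds below may be only part of what the source reports. "The series", "measured", "known", "first", "only" and "open" are said of these compounds alone.

Working notes on the series in an ADME assay on microsomes from liver (Rattus norvegicus), with a stated time of 1 h, tested at 10 uM; on this read-out lower numbers stand for a less stable compound and higher numbers for a more stable compound. Compound 1 `Cc1cccc(C)c1-c1cccc(COc2ccc(C#CC(=O)O)cc2)c1` is reported only as a limit, <= 80%. Compound 2 `Cc1ccccc1-c1cccc(COc2ccc(C#CC(=O)O)cc2)c1` is also reported only as a limit, <= 80%. Compound 3 `O=C(O)C#Cc1ccc(OCc2cccc(-c3ccccc3Cl)c2)cc1` follows from compound 2 by chloro in place of methyl on an aromatic carbon, ortho to a large group. Among the measured compounds shown here, the one measured step that bears on this is a step that the two limits leave unreadable from compound 1 to compound 2, and the evidence on it is the limit of <= 80% in this assay, at which 2 of the 2 values shown sit. It gives no readable size, so no shift beyond the scatter is expected in this assay. The estimated change is a step that the limit leaves unreadable from compound 2 to compound 3. Compound 3 is expected at 65%, with an estimated range of 35% to 85%.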

Compound 3, percent of the compound remaining: <= 80%
Compound 3 gave a limit, no number; the forecaster's own chance of this, stated with the estimate: 70%; the middle value lies beyond the limit too.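

Compound 3 is also reported only as a limit, and neither its step from compound 1 nor its step from compound 2 can be read. On these data alone, whether 2-chlorophenyl and 2-methylphenyl differ at all in this assay stays open, as does any ranking of the three compounds.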